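Swapping the amine substituent: compound 3 to compound 4

The compounds below may be only part of what the source reports. "The series", "measured", "known", "first", "only" and "open" are said of these compounds alone.

Measured in a functional assay on CHO cells for activation of 5-hydroxytryptamine receptor 1D (Homo sapiens), read by GTPgammaS binding (a higher number here means a larger maximal response, a lower number a smaller maximal response), so far:
- compound 1, `O[C@@H]1Cc2ccccc2[C@H]1NC1CCN(CCCc2c[nH]c3ccc(-n4cnnc4)cc23)CC1`, gives 75%
- compound 2, `c1cc(CNC2CCN(CCCc3c[nH]c4ccc(-n5cnnc5)cc34)CC2)co1`, gives 65%
- compound 3, `OCCC(NC1CCN(CCCc2c[nH]c3ccc(-n4cnnc4)cc23)CC1)c1ccccc1`, gives 100%

All three share one core and differ only in the group attached to the amine nitrogen on the saturated ring. Compound 3 gives the largest maximal response of the three: the change was a number 25 percentage points higher from compound 1 to compound 3 (beyond the scatter) and a number 35 percentage points higher from compound 2 to compound 3 (beyond the scatter), both beyond the scatter, while the change a number 10 percentage points lower from compound 1 to compound 2 (within the scatter) stays within it.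

Compound 4, `CC(C)=CCN(C)C1CCN(CCCc2c[nH]c3ccc(-n4cnnc4)cc23)CC1`, has not been measured. It differs from compound 3 in one place: methyl(3-methylbut-2-en-1-yl)amino in place of (3-hydroxy-1-phenylpropyl)amino on a saturated ring carbon. The two steps that reach compound 3 both bear on this change, since each replaced a different amine substituent with 3-hydroxy-1-phenylpropyl and raised the maximal response; removing that group again is therefore expected to lower it. For the measured compounds named here, none of the measured compounds carries a methyl(3-methylbut-2-en-1-yl)amino group, so how far the response falls is uncertain. A downward step of a number 30 percentage points lower from compound 3 to compound 4 (beyond the scatter) is expected, roughly back to the level of compound 1 and compound 2, and compound 4 is estimated at 70%, within a range from 50% to 95%.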

Compound 4, largest response reached (reported as efficacy), in percent of the reference or control that the assay uses: 115%
Compound 4: the middle estimate sits 45 percentage points below what was measured; measured number outside the range, above it.
By their numbers in this assay, from the lowest: compounds 2 and 1 (each within the scatter of the next); then compound 3; then compound 4.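

In this assay, the group on the amine nitrogen does not need a ring or a hydroxyl for a large maximal response: methyl(3-methylbut-2-en-1-yl)amino has neither, yet the step is a number 15 percentage points higher from compound 3 to compound 4 (beyond the scatter) and the group's hydrogen-bond donors fall to zero. Against the other two substituents the gain is wider, at a number 50 percentage points higher from compound 2 to compound 4 (beyond the scatter) and a number 40 percentage points higher from compound 1 to compound 4 (beyond the scatter) in turn, so compound 4 now gives the largest maximal response of the four, and this position tolerates an open chain with a double bond at least as well as any group tried so far. No supporting data are available to explain why this substituent gives the higher response.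

The change from compound 3 to compound 4 removes the six-membered aromatic ring and the hydroxyl and adds a methyl on the nitrogen in a single move, so the compounds shown cannot say which of these differences matters. The saturated 3-methylbutyl chain in place of the 3-methylbut-2-en-1-yl chain, or a hydrogen in place of the nitrogen's methyl, would begin to separate them.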